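Iodo to methylsulfanyl in a cytotoxicity read-out

The compounds below may be only part of what the source reports. "The series", "measured", "known", "first", "only" and "open" are said of these compounds alone.

Measured so far:
Compound 1 `CC[C@@H](Nc1nc(SC)nc2c1ccn2[C@H]1[C@H](O)[C@H](O)[C@]2(CO)C[C@H]12)C1CC1`: > 50000 nM (a limit)
Compound 2 `CC(C)[C@@H](Nc1nc(I)nc2c1ncn2[C@H]1[C@H](O)[C@H](O)[C@]2(CO)C[C@H]12)C1CC1`: 46000 nM

For the measured compounds named here, in an ADME assay on Vero 76 cells (Chlorocebus sabaeus) for cytotoxicity, read by neutral red uptake (on this read-out higher numbers stand for lower toxicity in this test and lower numbers for higher toxicity in this test), compound 2 gives 46000 nM, the only exact number so far. Compound 3 `CSc1nc(N[C@H](C(C)C)C2CC2)c2ncn([C@H]3[C@H](O)[C@H](O)[C@]4(CO)C[C@H]34)c2n1` has methylsulfanyl in place of iodo on an aromatic carbon. Compound 1 also carries methylsulfanyl, and its > 50000 nM is a limit of the assay. Going by the values given here, no pair of measured compounds sizes this change, so the expected step of a 1.1-fold higher number from compound 2 to compound 3 (0.04 log units; within the scatter) is none beyond the scatter. Compound 3 is estimated at 50000 nM, with an expected range of 25000 nM to 100000 nM.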

Compound 3, half-maximal cytotoxic concentration: > 100000 nM
Compound 3: only a limit was reported; the forecaster's own chance of this, stated with the estimate: 55%; middle value at least 2.0-fold (0.30 log units) from the limit.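

In this assay, methylsulfanyl in place of iodo on an aromatic carbon between two ring nitrogen atoms gives an at least 2.1-fold higher number from compound 2 to compound 3 (0.33 log units; beyond the scatter), so this change now has a measured lower bound at this position. The value of compound 3, > 100000 nM, is a limit, so the full size of the step stays unknown: the limit of > 100000 nM in this assay, at which 1 of the 3 values shown sits.

The compounds shown leave open how an amine, a methoxy group or the longer ethylsulfanyl chain on this carbon would read in this assay.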